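The source may hold more compounds than are shown below. What is called first, only, known or untested is meant among the compounds shown, and "the series" means these compounds.

In a functional assay on HT-29 cells (Homo sapiens) for inhibition, read by luminescence and CellTiter-Glo, with a stated time of 24 h (on this read-out higher numbers stand for an effect only at larger amounts of compound and lower numbers for an effect already at smaller amounts), compound 3 `CN1C(=S)[C@@H](NC(=O)c2nc(Cc3ccccc3)n(C3CCC3)n2)COc2ccccc21` gives 181 nM as the lowest of three numbers, while compound 1 `CC(C)CCn1nc(C(=O)N[C@H]2COc3ccccc3N(C)C2=S)nc1Cc1ccccc1` gives 3640 nM and compound 2 `CN1C(=S)[C@@H](NC(=O)c2nc(Cc3ccccc3)n(CCCF)n2)COc2ccccc21` gives 4760 nM in a pair lying within the scatter. Compound 4 `CN1C(=S)[C@@H](NC(=O)c2nc(Cc3ccccc3)n(C3CCCCCC3)n2)COc2ccccc21` carries cycloheptyl in place of cyclobutyl on an aromatic nitrogen and is otherwise unchanged. Among the measured compounds shown here, two measured steps bear on this place, a 20-fold lower number from compound 1 to compound 3 (1.30 log units; beyond the scatter) and a 26-fold lower number from compound 2 to compound 3 (1.42 log units; beyond the scatter), both large and both leading from an open chain to cyclobutyl. Neither tests a larger ring, so their size transfers only loosely. In this assay a higher number is expected, probably beyond the scatter yet short of those steps, with an estimated 3.9-fold higher number from compound 3 to compound 4 (0.59 log units; beyond the scatter) for this change. Compound 4 is estimated at 700 nM within an expected range from 150 nM to 3000 nM in this assay.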

Compound 4, half-maximal effective concentration: 5530 nM
Compound 4: middle estimate off by 7.9-fold (0.90 log units), on the low side, outside the stated range (above it).
By their numbers in this assay, from the lowest: compound 3; then compounds 1, 2 and 4 (each within the scatter of the next).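

In this assay cycloheptyl in place of cyclobutyl on the aromatic nitrogen gives a 31-fold higher number from compound 3 to compound 4 (1.49 log units; beyond the scatter) and removes the advantage of compound 3, so that advantage does not extend to every carbon ring at this place. Compound 4 cannot be separated from the open-chain compounds, with a 1.2-fold higher number from compound 2 to compound 4 (0.07 log units; within the scatter) and a 1.5-fold higher number from compound 1 to compound 4 (0.18 log units; within the scatter), so having a ring here is not enough on its own. Nothing measured here explains this difference. Cyclopentyl and cyclohexyl would show where between the four-membered and seven-membered rings the number rises. Cyclopropyl and a branched tert-butyl group also remain open.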